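Compound 3: naphthalen-1-yl in place of the benzodioxin group

The source may report more compounds than this note shows. Statements on the series, on what has been measured and on what is new or still open speak of the compounds shown alone.

Among the compounds with values here, in a functional assay on MDA-MB-231 cells (Homo sapiens) for antiproliferative activity, with a stated time of 5 days (a higher number here means a weaker inhibitor, a lower number a stronger inhibitor), compound 1 `CC1OC2(C=CC(=O)C=C2)N(c2nc(-c3ccc4ccccc4c3)nn2-c2ccccc2)C1=O` gives 70 nM and compound 2 `O=C1C=CC2(C=C1)OCC(=O)N2c1nc(-c2ccc3c(c2)OCCO3)nn1-c1ccccc1` gives 100 nM as the two numbers so far. These two values lie within the scatter of each other, so compound 2 stands level with compound 1. Within the data shown here, the two compounds differ in more than one place, and no single-change step links them.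

Compound 3 `O=C1C=CC2(C=C1)OCC(=O)N2c1nc(-c2cccc3ccccc23)nn1-c1ccccc1` has not yet been measured. It differs from compound 2 in one place, on an aromatic carbon of a five-membered aromatic ring with 3 nitrogen, where naphthalen-1-yl stands in place of 2,3-dihydro-1,4-benzodioxin-6-yl naphthalen-1-yl in place of 2,3-dihydro-1,4-benzodioxin-6-yl on an aromatic carbon on the shared core.

Among the measured compounds shown here, no measured step covers this change. Compound 1 also carries two six-membered aromatic rings of carbon only at that place and gives 70 nM in this assay as its value. On that comparison alone, no step beyond the scatter is expected in either direction. The estimated step is a 1.2-fold higher number from compound 2 to compound 3 (0.08 log units; within the scatter) and remains an expectation only. Compound 3 is estimated at 120 nM with an expected range from 40 nM to 350 nM on the same measure.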

Compound 3, half-maximal inhibitory concentration: 50 nM
Estimate against measurement, compound 3: 2.4-fold (0.38 log units) above, within the range that was stated.
By their numbers in this assay, from the lowest: compounds 3, 1 and 2 (each within the scatter of the next).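

Within the data shown here, this is the first step read at this position, on an aromatic carbon of a five-membered aromatic ring with 3 nitrogen, and it comes with the rest of the structure held fixed. In this assay, naphthalen-1-yl in place of 2,3-dihydro-1,4-benzodioxin-6-yl gives a 2.0-fold lower number from compound 2 to compound 3 (0.30 log units; within the scatter), so compound 2 and compound 3 stand level. Both groups have 10 heavy atoms, but the entering group has 2 six-membered aromatic rings of carbon only and 0 hydrogen-bond acceptors, where the leaving group has 2 hydrogen-bond acceptors and a six-membered non-aromatic ring, so in this one pair the two ring oxygens are not needed to keep the value within the scatter. Nothing measured here explains why these two groups read alike.

The compounds shown give only this one single-change step at this position, which is too little to support a trend across groups there. On these data alone, how an amine or a carboxylic acid on the same aromatic carbon would read in this assay stays open, as does a longer chain in place of the fused rings.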